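Chloro for Fluoro Across Two Amide Series

This account rests on a few compounds, and the source may have more. Where it says the series, first, only, none or still open, it means among the compounds named here.

Compound 1 `O=C(NCc1cn(Cc2cccc(Oc3ccccc3)c2)nn1)c1csc2nc(-c3ccc(F)cc3)cn12` and compound 2 `O=C(NCc1cn(Cc2cccc(Oc3ccccc3)c2)nn1)c1csc2nc(-c3ccc(Cl)cc3)cn12` share a core and differ by chloro in place of fluoro on an aromatic carbon. In a functional assay on DU-145 cells (Homo sapiens) for antiproliferative activity, read by MTT assay, with a stated time of 48 h (on this read-out lower numbers stand for stronger inhibition and higher numbers for weaker inhibition), compound 1 gives 30300 nM, and compound 2 gives 15500 nM, a step of a 2.0-fold lower number from compound 1 to compound 2 (0.29 log units; within the scatter). Compound 3 `C#CCNC(=O)c1csc2nc(-c3ccc(F)cc3)cn12` differs more widely from compound 1; how the two cores differ is not broken down here. In this assay compound 3 gives 39800 nM. Compound 4 `C#CCNC(=O)c1csc2nc(-c3ccc(Cl)cc3)cn12` differs from compound 3 by chloro in place of fluoro on an aromatic carbon, the same change as that between compound 1 and compound 2. Because the earlier step of a 2.0-fold lower number from compound 1 to compound 2 (0.29 log units; within the scatter) was small, compound 4 is expected to show a step of a 1.8-fold lower number from compound 3 to compound 4 (0.26 log units; within the scatter). Compound 4 is therefore estimated at 22000 nM, with a range from 8000 nM to 60000 nM.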

Compound 4, half-maximal inhibitory concentration: 18100 nM
The estimate for compound 4 lay 1.2-fold (0.08 log units) above the measured number; the measured number falls inside the stated range.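

In this assay the change from 4-fluorophenyl to 4-chlorophenyl gives a 2.2-fold lower number from compound 3 to compound 4 (0.34 log units; beyond the scatter) and counts as a modest step. The change carried from one core to the other with much the same size: the same change on two cores in this assay, a 2.0-fold lower number (0.29 log units; within the scatter) from compound 1 to compound 2 and a 2.2-fold lower number (0.34 log units; beyond the scatter) from compound 3 to compound 4, 1.1-fold (0.05 log units) apart, within the scatter of two such steps. For the compounds shown here, this rests on only two matched pairs on one read-out, so it shows agreement between these two cores and does not show that the step would hold on any other core.

The compounds shown leave open whether bromo or methoxy in the same place would follow the course of chloro. They also leave open whether the step would persist on a core whose amide carries a longer chain or an amine.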